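Hydrazino in place of piperidinyl on the quinoxaline core

This account rests on a few compounds, and the source may have more. Where it says the series, first, only, none or still open, it means among the compounds named here.

Measured compounds:
compound 1, `Cc1nc2cc(Br)ccc2nc1N1CCCCC1`, 0.0403 ug/mL
compound 2, `Cc1nc2cc(Br)ccc2nc1Nc1ccc(S(=O)(=O)N2CCCCC2)cc1`, 0.00067 ug/mL

In a functional assay on NCI-H460 cells (Homo sapiens) for inhibition, read by sulforhodamine B assay, with a stated time of 72 h (a lower number here means a stronger inhibitor, a higher number a weaker inhibitor), compound 1 gives 0.0403 ug/mL, the higher of the two numbers recorded so far. Compound 2 gives 0.00067 ug/mL in this assay, a lower number by a margin that lies beyond the scatter. Compound 3, `Cc1nc2cc(Br)ccc2nc1NN`, has not yet been measured. The change from compound 1 to compound 3 is aminoamino in place of piperidin-1-yl on an aromatic carbon. Among the compounds with values here, no measured pair of compounds that differ in only this one place is available, so the size of this step cannot be read from the data. The account expects the number for compound 3 to rise, by roughly a 5.0-fold higher number from compound 1 to compound 3 (0.70 log units; beyond the scatter), since the larger ring of compound 1 is replaced by a much smaller group. Compound 3 is therefore estimated at 0.2 ug/mL, with a range from 0.03 ug/mL to 1.5 ug/mL.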

Compound 3, half-maximal inhibitory concentration: 0.0206 ug/mL
Compound 3: the middle estimate sits 9.7-fold (0.99 log units) above what was measured; the whole stated range lies above it.
By their numbers in this assay, from the lowest: compound 2; then compounds 3 and 1 (each within the scatter of the next).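

In this assay, the change to aminoamino gives (a 2.0-fold lower number from compound 1 to compound 3 (0.29 log units; within the scatter)), so this aromatic carbon of the shared core can carry either piperidin-1-yl, with 6 heavy atoms and one six-membered non-aromatic ring, or aminoamino, with 2 heavy atoms and no ring, while the numbers stay within the scatter of each other. For this one pair, then, the loss of the ring and the gain from 0 to 2 hydrogen-bond donors leave no change that can be told from the scatter. Nothing measured here accounts for this result.

The compounds shown leave open how a plain amino group, a methylamino group or a morpholin-4-yl ring would read on the same carbon. They also leave open whether a longer chain ending in an amine would stay within the scatter of compound 3.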